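The source may report more compounds than this note shows. Statements on the series, on what has been measured and on what is new or still open speak of the compounds shown alone.

Measured compounds:
compound 1 `O=c1ccn(CCN2CCCCC2)c(CO)c1O` — 0.019 in a physicochemical assay for lipophilicity; a lower number here means a more polar compound, a higher number a more lipophilic compound
compound 2 `Cn1cc(O)c(=O)cc1CN1CCCCC1` — 0.64 in this assay
compound 3 `CCn1ccc(=O)c(O)c1C(C)O` — -0.557 in this assay

Among these three, compound 2 stands highest in this assay. Its nearest neighbour is compound 1, whose number is lower by a gap beyond the scatter, and compound 3 sits furthest down, again beyond the scatter. No pair of these compounds differs in only one place, so no single step between measured compounds can be read off.

The unmeasured compound 4 `O=c1cc(CN2CCCCC2)n(CCN2CCCCC2)cc1O` is related to compound 2 by a single change: (piperidin-1-yl)methyl in place of hydrogen on a saturated chain carbon bound to an aromatic nitrogen. For the measured compounds named here, there is no measured pair here that shows what this particular change does in this assay, so the expectation rests on the general observation that the added group brings more carbon atoms and a ring but also a basic nitrogen that can take up a charge. Taken together, a small rise is expected, one that may well stay near the scatter: the step from compound 2 to compound 4 is estimated at a number 0.26 log units higher from compound 2 to compound 4 (within the scatter). Compound 4 is therefore expected to give about 0.9, somewhere between 0.2 and 1.6.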

Compound 4, partition coefficient: 1.84
Compound 4: middle estimate off by 0.94 log units, on the low side; measured number above the stated range.
By their numbers in this assay, from the lowest: compound 3; then compound 1; then compound 2; then compound 4.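

In this assay, for the compounds shown here, (piperidin-1-yl)methyl in place of hydrogen on a saturated chain carbon bound to an aromatic nitrogen gives a step of a number 1.20 log units higher from compound 2 to compound 4 (beyond the scatter), the first direct reading of any single change. At this position, then, adding these 7 heavy atoms, one of them nitrogen, goes with a large rise rather than a step lost in the scatter. No measurement shown accounts for the size of this rise.

The compounds shown leave open how much of the step belongs to the ring carbons and how much to the ring nitrogen. From the compounds shown here alone, what a plain hexyl chain or a morpholine ring on the same carbon would do in this assay also remains unknown.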